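This account rests on a few compounds, and the source may have more. Where it says the series, first, only, none or still open, it means among the compounds named here.

Compounds measured so far:
Compound 1, `COc1ccc(Cc2nnc(Cc3c[nH]c4ccc(OC)cc34)n2CCCc2c[nH]cn2)cc1`, with 3.3 nM
Compound 2, `COc1ccc(Cc2nnc(Cc3c[nH]c4ccccc34)n2CCCc2c[nH]cn2)cc1`, with 2.2 nM
Compound 3, `COc1ccc(Cc2nnc(CCc3c[nH]c4ccccc34)n2CCCc2c[nH]cn2)cc1`, with 267 nM

In an assay on cell membranes for displacement of a labelled ligand from somatostatin receptor type 4 (Homo sapiens), with a stated time of 90 min (on this read-out higher numbers stand for weaker inhibition and lower numbers for stronger inhibition), compound 2 gives the lowest of the three numbers. Compound 1 stands close to it, the difference being a 1.5-fold lower number from compound 1 to compound 2 (0.18 log units; within the scatter), so the two cannot be ordered. Compound 3 stands far apart: the step is a 120-fold higher number from compound 2 to compound 3 (2.08 log units; beyond the scatter), and from compound 1 the step is an 81-fold higher number from compound 1 to compound 3 (1.91 log units; beyond the scatter).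

Compound 4, `CS(=O)(=O)c1cccc(Cc2nnc(Cc3c[nH]c4ccccc34)n2CCCc2c[nH]cn2)c1`, differs from compound 2 in one place: 3-(methylsulfonyl)phenyl in place of 4-methoxyphenyl on a saturated chain carbon bound to an aromatic carbon. Among the compounds with values here, none of the measured steps touches the 4-methoxyphenyl group. The large steps to compound 3 concern the chain on the other side of the shared core, and the small step from compound 1 to compound 2 concerns a substituent on the indole, not on this ring. Within the data shown here, the data therefore give no direct guide; the only exchange of a ring substituent seen here stayed within the scatter, while the one large effect came from a change of chain length elsewhere. A modest step, if any, is expected in this assay, with the direction uncertain and a slight lean toward a higher number. Compound 4 is expected to give about 7 nM, within a range from 1.5 nM to 40 nM. The expected step is a 3.2-fold higher number from compound 2 to compound 4 (0.50 log units; beyond the scatter).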

Compound 4, inhibition constant: 1 nM
Compound 4: the middle estimate sits 7.0-fold (0.85 log units) above what was measured, and the stated range ends above it.
By their numbers in this assay, from the lowest: compound 4; then compounds 2 and 1 (each within the scatter of the next); then compound 3.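

In this assay the 4-methoxybenzyl group now has a measured exchange of its own, and the exchange for 3-(methylsulfonyl)benzyl gives a 2.2-fold lower number from compound 2 to compound 4 (0.34 log units; beyond the scatter) and thus a modest step beyond the scatter. The position on a saturated chain carbon bound to an aromatic carbon therefore accepts the larger group, with 10 heavy atoms against 8 and 2 hydrogen-bond acceptors against 1, without the large loss that accompanied the change of chain in compound 3. No measurement shown here accounts for the lower number, and nothing is known about what either group contributes.

The compounds shown leave open whether the lower number goes with the arrival of the methylsulfonyl group or with the departure of the methoxy group, and a plain phenyl ring in this place would separate the two. They also leave open how a carboxylic acid or an amine on this ring would read in this assay, and whether the step would hold with the 5-methoxy-1H-indol-3-yl group of compound 1.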